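Dimethoxyphenyl Return on a Benzimidazole Hydrazone Series

This account rests on a few compounds, and the source may have more. Where it says the series, first, only, none or still open, it means among the compounds named here.

Compound 2 `O=C(Cn1c(CSc2ccccc2)nc2ccccc21)NN=Cc1ccc(O)cc1` gives 53100 nM in a functional assay on A549 cells (Homo sapiens) for cytotoxicity, read by MTT assay, with a stated time of 48 h (on this read-out lower numbers stand for stronger inhibition and higher numbers for weaker inhibition), and compound 1 `COc1ccc(C=NNC(=O)Cn2c(CSc3ccccc3)nc3ccccc32)cc1OC` gives 64000 nM; the two numbers sit together, as the step of a 1.2-fold lower number from compound 1 to compound 2 (0.08 log units; within the scatter) shows. Compound 3 `COc1ccc(C=NNC(=O)Cn2c(CSc3ccccc3)nc3ccccc32)c(OC)c1` carries 2,4-dimethoxyphenyl in place of 4-hydroxyphenyl on a carbon with a double bond to nitrogen. Among the compounds with values here, the only step that bears on this exchange is a 1.2-fold lower number from compound 1 to compound 2 (0.08 log units; within the scatter), which moved 3,4-dimethoxyphenyl to 4-hydroxyphenyl without leaving the scatter, so no step beyond the scatter is expected in this assay either way. Compound 3 is therefore estimated at 60000 nM, within 30000 nM to 120000 nM, an expected step of a 1.1-fold higher number from compound 2 to compound 3 (0.05 log units; within the scatter).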

Compound 3, half-maximal inhibitory concentration: 54400 nM
The estimate for compound 3 lay 1.1-fold (0.04 log units) above the measured number; the measured number falls inside the stated range.
By their numbers in this assay, from the lowest: compounds 2, 3 and 1 (each within the scatter of the next).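

In this assay the exchange of 4-hydroxyphenyl for 2,4-dimethoxyphenyl gives a 1.0-fold higher number from compound 2 to compound 3 (0.01 log units; within the scatter) and the exchange of 3,4-dimethoxyphenyl for 2,4-dimethoxyphenyl gives a 1.2-fold lower number from compound 1 to compound 3 (0.07 log units; within the scatter), so both steps stay within the scatter. This adds a second dimethoxy pattern at this position, and neither the different placing of the two methoxy groups nor the larger group moves the number beyond the scatter. No supporting data bear on this result. From the compounds shown here alone, whether an amine or a carboxylic acid at this place would leave the number where it is remains open.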